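This account rests on a few compounds, and the source may have more. Where it says the series, first, only, none or still open, it means among the compounds named here.

Measured compounds:
compound 1, `COc1ccccc1-c1cc(C(=O)NCCCN2CCCC2)c2cn[nH]c2n1`: 14500 nM
compound 2, `COc1cc(C(=O)NCCCN2CCCC2)cc(-c2ccccc2C)c1`: 22100 nM
compound 3, `Cc1ccccc1-c1cc(C(=O)NCCCN2CCCC2)ccn1`: 8800 nM

Of the compounds shown here, three have been tested in an assay on isolated protein for inhibition of N-lysine methyltransferase SMYD2 (Homo sapiens); a lower number here means a stronger inhibitor, a higher number a weaker inhibitor. Compound 3 gives the lowest number of the three in this assay, 8800 nM. Compound 1 lies nearest to it, and the gap between compound 1 and compound 3 is within the scatter, so the two cannot be told apart. Compound 2 lies furthest from compound 3, and that gap is beyond the scatter; compound 2 gives the higher number.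

Compound 4, `COc1cc(C(=O)NCCCN2CCCC2)cc(-c2ccccc2C)n1`, has not yet been measured. It differs from compound 3 in one place: methoxy in place of hydrogen on an aromatic carbon, on an aromatic carbon of a six-membered aromatic ring with one nitrogen, next to the ring nitrogen and meta to the 2-methylphenyl group. Within the data shown here, no measured pair shows this exact change, so there is no step to lean on. Compound 2 carries a methoxy on a ring without nitrogen and gives a higher number than compound 3, but it also differs elsewhere, so it does not settle the matter.

On this basis compound 4 is expected to land close to compound 3, with an expected step of a 1.3-fold higher number from compound 3 to compound 4 (0.10 log units; within the scatter) that may not go beyond the scatter, and perhaps toward a somewhat higher number. The estimate for compound 4 in this assay is 11000 nM, with a range from 4000 nM to 30000 nM.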

Compound 4, half-maximal inhibitory concentration: 9900 nM
Compound 4: middle estimate off by 1.1-fold (0.05 log units), on the high side, and the stated range covers the measured number.
By their numbers in this assay, from the lowest: compounds 3, 4, 1 and 2 (each within the scatter of the next, the first and the last beyond it).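

In this assay, methoxy in place of hydrogen on an aromatic carbon, next to the ring nitrogen and meta to the 2-methylphenyl group, gives a 1.1-fold higher number from compound 3 to compound 4 (0.05 log units; within the scatter). This is the first change in one place among these compounds, and it shows that this position can carry a methoxy with no shift that stands out from the scatter. Compound 4 also pairs with compound 2, which has a ring without nitrogen and otherwise matches it: compound 4 gives 9900 nM and compound 2 gives 22100 nM, so the methoxy on the nitrogen-containing ring sits at a number much like that of compound 3, and nothing shown here gives a measured reason for this result.

As far as these compounds go, a single group at this position cannot show how far it accepts change, so the effect of an amine, a carboxylic acid or a longer chain such as ethoxy in the place of the methoxy remains open. Whether the same methoxy would behave alike on the core of compound 1 also stays unanswered.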